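The source may hold more compounds than are shown below. What is called first, only, known or untested is meant among the compounds shown, and "the series" means these compounds.

Measured compounds:
compound 1 `Cn1nnnc1SCC(=O)N/N=c1/scc(-c2ccc(C#N)cc2)n1-c1ccccc1`, 35.6% in a functional assay on C6 cells (Rattus norvegicus) for cytotoxicity, read by MTT assay, with a stated time of 24 h, tested at 50 ug/mL; on this read-out lower numbers stand for a stronger effect and higher numbers for a weaker effect at the one concentration tested
compound 2 `Cn1nnnc1SCC(=O)N/N=c1/scc(-c2ccc([N+](=O)[O-])cc2)n1-c1ccccc1`, 69.2% in this assay
compound 3 `O=C(CSc1nnnn1-c1ccccc1)N/N=c1/scc(-c2ccccc2)n1-c1ccccc1`, 36.7% in this assay

In this assay compound 3 sits with compound 1, the two numbers lying within the scatter of each other, while compound 2 lies well apart from both of them. For the measured compounds named here, the only measured step with a single change, a number 33.6 percentage points higher from compound 1 to compound 2 (beyond the scatter), concerns the group on the aromatic ring attached to the shared core and not the tetrazole. Compound 4 `Cn1nnnc1SCC(=O)N/N=c1/scc(-c2ccccc2)n1-c1ccccc1` differs from compound 3 in that (methyl in place of phenyl on an aromatic nitrogen). Going by the values given here, no measured pair isolates this change, so the step cannot be read from a directly matching precedent. Compound 4 carries the same methyl-bearing tetrazole as compound 1 and the same unsubstituted aromatic ring as compound 3, and both of those compounds give numbers close to one another in this assay. Compound 4 is therefore expected to give a number close to compound 3, with an estimated step of a number 1.3 percentage points higher from compound 3 to compound 4 (within the scatter), which would be within the scatter. The estimate for compound 4 in this assay is 38%, with a range from 25% to 55%.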

Compound 4, a percentage reported as activity, at one concentration (the size of the read-out at that concentration, not a potency): 56.2%
Compound 4: middle estimate off by 18.2 percentage points, on the low side; the whole stated range lies below it.
By their numbers in this assay, from the lowest: compounds 1 and 3 (each within the scatter of the next); then compound 4; then compound 2.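

Replacing phenyl with methyl on the aromatic nitrogen of the tetrazole gives a number 19.5 percentage points higher from compound 3 to compound 4 (beyond the scatter) in this assay and so shows that this position bears on the read-out, with the phenyl form giving the stronger effect. With the methyl-bearing tetrazole held constant, the unsubstituted ring now gives a reference point: the loss of cyano gives a number 20.6 percentage points higher from compound 1 to compound 4 (beyond the scatter) and the loss of nitro gives a number 13 percentage points lower from compound 2 to compound 4 (beyond the scatter) in this read-out, so the two groups pull in opposite directions relative to hydrogen. Nothing available gives a reason for these steps.

For the compounds shown here, the phenyl to methyl change is seen only with the unsubstituted ring, so it remains open whether it holds with cyano or nitro on that ring. Also open, on these data alone, is how an ethyl or benzyl group on the tetrazole nitrogen, or an amine on the aromatic ring, would read.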